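A Methyl Added to the Core of Compound 3

This account rests on a few compounds, and the source may have more. Where it says the series, first, only, none or still open, it means among the compounds named here.

Of the compounds shown here, three have been measured in a functional assay on the whole organism (strain Wistar Albino) for inhibition, with Rattus norvegicus as the target, read by paw edema, with a stated time of 1 h, at a dose of 20 mg/kg; on this read-out lower numbers stand for less inhibition and higher numbers for more inhibition at the one dose given (going by the name of the read-out). Compound 1 `Cc1cc(-c2nn3c(-c4ccoc4C)nnc3s2)c2ccccc2n1` gives 7.23%. Compound 2 `Cc1occc1-c1nnc2sc(-c3ccnc4ccccc34)nn12` gives 12.5%. Compound 3 `COc1ccc2[nH]cc(Cc3nn4c(Cc5ccc(OC)c(OC)c5)nnc4s3)c2c1` gives 4.11%; how its core differs from that of compound 2 is not broken down here. The change from compound 2 to compound 1 is methyl in place of hydrogen on an aromatic carbon and it made a number 5.3 percentage points lower from compound 2 to compound 1 (within the scatter).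

Compound 4 `COc1ccc2[nH]c(C)c(Cc3nn4c(Cc5ccc(OC)c(OC)c5)nnc4s3)c2c1` is not yet measured. It differs from compound 3 by methyl in place of hydrogen on an aromatic carbon. This is the same kind of change as that from compound 2 to compound 1, but the place is not the same: in compound 1 the methyl sits on a six-membered aromatic ring with one nitrogen, next to the ring nitrogen, meta to a fused ring, meta to a large group and para to a fused ring, whereas in compound 4 it sits on a five-membered aromatic ring with one nitrogen, next to the ring nitrogen and next to the ring atom that bears a large group.

Beside the earlier step, the step from compound 3 to compound 4 is expected to be a number 0.1 percentage points lower from compound 3 to compound 4 (within the scatter), because the earlier step was a number 5.3 percentage points lower from compound 2 to compound 1 (within the scatter) and because compound 3 gives 4.11%. Compound 4 is thus estimated at 4%, expected to fall between 0% and 12%.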

Compound 4, a percentage reported as inhibition, in the whole organism at one dose (the size of the read-out at that dose, not a potency): 10.5%
The estimate for compound 4 lay 6.5 percentage points below the measured number, within the range that was stated.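

In this assay, methyl in place of hydrogen on an aromatic carbon gave a number 6.4 percentage points higher from compound 3 to compound 4 (within the scatter), so this step alone cannot be told apart from no effect. Set beside the earlier step on another core, the same change gives no difference that can be read: the same change on two cores in this assay, a number 5.3 percentage points lower (within the scatter) from compound 2 to compound 1 and a number 6.4 percentage points higher (within the scatter) from compound 3 to compound 4, 11.7 percentage points apart, within the scatter of two such steps This does not show that the change carries over equally from one core to another, for neither step stands clear of the scatter, the methyl sits on a different ring in each pair, and two pairs are too few to support a rule for the series.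

The compounds shown leave open how a larger or different group in the same place, such as an ethyl group, a chlorine atom or an amine, would read in this assay. They also leave open whether a step that stands clear of the scatter can be reached at this place on the core of compound 3 at all.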